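A Fluoro-to-Chloro Swap at the Strongest Compound

The compounds below may be only part of what the source reports. "The series", "measured", "known", "first", "only" and "open" are said of these compounds alone.

In a functional assay on CHO cells with adenosine receptor A1 (Homo sapiens) as the target, read by cAMP accumulation and immunoassay, with a stated time of 6 min, tested at 10 uM (on this read-out lower numbers stand for a stronger effect and higher numbers for a weaker effect at the one concentration tested), compound 3 `Nc1scc(CN2CCN(c3ccc(F)c(F)c3)CC2)c1C(=O)c1ccc(Cl)cc1` gives -87%, the lowest of the three numbers. Compound 1 `Nc1scc(CN2CCN(c3ccc(OC(F)(F)F)cc3)CC2)c1C(=O)c1ccc(Cl)cc1` gives -74% and compound 2 `Nc1scc(CN2CCN(C3CCCCCC3)CC2)c1C(=O)c1ccc(Cl)cc1` gives -25%, so the step of a number 13 percentage points lower from compound 1 to compound 3 (beyond the scatter) was modest while a number 62 percentage points lower from compound 2 to compound 3 (beyond the scatter) was large. Compound 4 `Nc1scc(CN2CCN(c3ccc(F)c(Cl)c3)CC2)c1C(=O)c1ccc(Cl)cc1` differs from compound 3 by chloro in place of fluoro on an aromatic carbon. Among the measured compounds shown here, no measured step swaps one halogen for another; the steps seen replace the whole 3,4-difluorophenyl group. Because a number 13 percentage points lower from compound 1 to compound 3 (beyond the scatter) was only modest for a larger change, a step within the scatter, a number 2 percentage points higher from compound 3 to compound 4 (within the scatter), is expected here. Compound 4 is therefore expected to give about -85%, between -100% and -65%.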

Compound 4, a percentage reported as activity, at one concentration (the size of the read-out at that concentration, not a potency): -78%
Compound 4: middle estimate off by 7 percentage points, on the low side, within the range that was stated.
By their numbers in this assay, from the lowest: compounds 3, 4 and 1 (each within the scatter of the next, the first and the last beyond it); then compound 2.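

In this assay chloro can take the place of fluoro on this aromatic carbon, ortho to a fluoro group, with a number 9 percentage points higher from compound 3 to compound 4 (within the scatter) and so no real change. The 3-chloro-4-fluorophenyl group keeps a wide lead over cycloheptyl, with a number 53 percentage points lower from compound 2 to compound 4 (beyond the scatter) as the step, and stands level with 4-(trifluoromethoxy)phenyl, with a number 4 percentage points lower from compound 1 to compound 4 (within the scatter) as the step. Nothing measured here gives a reason for these results. On these data alone, whether bromo or methyl on the same carbon would hold the read-out equally well stays open. A single tested concentration also leaves the potency of these compounds unsettled.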